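The compounds below may be only part of what the source reports. "The series", "measured", "known", "first", "only" and "open" are said of these compounds alone.

In a functional assay on KARPAS-422 cells (Homo sapiens) for inhibition, read by luminescence and CellTiter-Glo, with a stated time of 14 days (a lower number here means a stronger inhibitor, a higher number a weaker inhibitor), compound 1 `CN(c1ncco1)c1cnc(NCc2c(F)ccc3c2CCO3)n2cnnc12` gives 20 nM. Going by the values given here, compound 2 `Cc1ncccc1-c1cnc(NCc2c(F)ccc3c2CCO3)c2cn[nH]c(=O)c12` gives 39.8 nM, and these two numbers lie within the usual scatter of each other, so compound 1 stands level with the only other compound measured. Compound 3 `CN(c1ccn(C)n1)c1cnc(NCc2c(F)ccc3c2CCO3)n2cnnc12` keeps the core of compound 1 but carries 1-methyl-1H-pyrazol-3-yl in place of 1,3-oxazol-2-yl on a nitrogen on an aromatic ring. Among the compounds with values here, no measured pair shows such a swap, so no step beyond the scatter is expected. The expected result is a 1.5-fold higher number from compound 1 to compound 3 (0.18 log units; within the scatter). Compound 3 is estimated at 30 nM, with an expected range from 8 nM to 110 nM.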

Compound 3, half-maximal inhibitory concentration: 25.1 nM
Compound 3: the middle estimate sits 1.2-fold (0.08 log units) above what was measured, and the stated range covers the measured number.
By their numbers in this assay, from the lowest: compounds 1, 3 and 2 (each within the scatter of the next).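

In this assay the swap of 1,3-oxazol-2-yl for 1-methyl-1H-pyrazol-3-yl gives a 1.3-fold higher number from compound 1 to compound 3 (0.10 log units; within the scatter) and so leaves compound 3 level with compound 1. This first pair at the position shows that on this nitrogen one five-membered aromatic ring can stand in for another, even with one more heavy atom, and the number stays within the scatter. No measured evidence here explains why the two groups read alike. Still open, going by these compounds, is whether a six-membered aromatic ring such as pyridine, or a saturated ring such as morpholine, would hold the number at this place.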